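Fused Bicyclic Amine on a Quinolone Topoisomerase Inhibitor Series

The source may hold more compounds than are shown below. What is called first, only, known or untested is meant among the compounds shown, and "the series" means these compounds.

Three compounds share one core. Compound 1 `CNCCNc1cc2c(cc1F)c(=O)c(C(=O)O)cn2Cc1ccc(-c2ccccc2)cc1` gives only a limit, > 200000 nM, in an assay on isolated protein for inhibition of DNA topoisomerase 1 (Homo sapiens), with a stated time of 15 min; on this read-out lower numbers stand for stronger inhibition and higher numbers for weaker inhibition. Compound 2 `CNCCCNc1cc2c(cc1F)c(=O)c(C(=O)O)cn2Cc1ccc(-c2ccccc2)cc1` gives 63600 nM in this assay, and compound 3 `CNC[C@@H]1CCN(c2cc3c(cc2F)c(=O)c(C(=O)O)cn3Cc2ccc(-c3ccccc3)cc2)C1` gives 168000 nM. Compound 3 thus holds the highest of the two numbers; the nearest is compound 2, with a 2.6-fold higher number from compound 2 to compound 3 (0.42 log units; beyond the scatter), while an at least 1.1-fold lower number from compound 1 to compound 3 (0.07 log units; that floor lies within the scatter) rests on a limit (the limit of > 200000 nM in this assay, at which 1 of the 3 values shown sits). Compound 4 `O=C(O)c1cn(Cc2ccc(-c3ccccc3)cc2)c2cc(N3C[C@H]4CCNC[C@H]4C3)c(F)cc2c1=O` carries a group of 9 heavy atoms (7 carbon, 2 nitrogen; one five-membered non-aromatic ring with 1 hetero atom, one six-membered non-aromatic ring with 1 hetero atom) in place of a group of 8 heavy atoms (6 carbon, 2 nitrogen; one five-membered non-aromatic ring with 1 hetero atom), on an aromatic carbon. Among the compounds with values here, the steps measured so far, an at least 3.1-fold lower number from compound 1 to compound 2 (0.49 log units; beyond the scatter) and a 2.6-fold higher number from compound 2 to compound 3 (0.42 log units; beyond the scatter), all stay modest, and no measured step covers a fused bicyclic amine, so compound 4 is expected to differ little from compound 3, with a 1.4-fold lower number from compound 3 to compound 4 (0.15 log units; within the scatter) foreseen. The estimate for compound 4 in this assay is 120000 nM, within 40000 nM to 300000 nM.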

Compound 4, half-maximal inhibitory concentration: 61000 nM
For compound 4 the middle estimate is 2.0-fold (0.29 log units) above the measured one; the measured number falls inside the stated range.
By their numbers in this assay, from the lowest: compounds 4 and 2 (each within the scatter of the next); then compound 3. At a limit, above all of these: compound 1.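

Replacing 3-((methylamino)methyl)pyrrolidin-1-yl with a fused two-ring amine on this aromatic carbon shows that a second ring does not weaken inhibition; the number falls (a 2.8-fold lower number from compound 3 to compound 4 (0.44 log units; beyond the scatter)). The fused amine and the open (3-(methylamino)propyl)amino chain cannot be told apart (a 1.0-fold lower number from compound 2 to compound 4 (0.02 log units; within the scatter)), so a ring-bearing amine can match the better chain here. The step from the shorter chain rests on a limit (an at least 3.2-fold lower number from compound 1 to compound 4 (0.51 log units; beyond the scatter)): (the limit of > 200000 nM in this assay, at which 1 of the 4 values shown sits).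

Going by these compounds, it remains open whether the other stereoisomer of the fused amine reads the same. On these data alone, how a piperazine or a fused amine with a primary amine would read here also remains open.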